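The source may report more compounds than this note shows. Statements on the series, on what has been measured and on what is new or still open speak of the compounds shown alone.

Going by the values given here, compound 3 `CCOc1ccc(OCCOCCNC2CCCC2)cc1` stands highest of the three numbers so far in a functional assay on SK-OV-3 cells (Homo sapiens) for inhibition, read by CCK-8 assay, with a stated time of 70 h (on this read-out lower numbers stand for stronger inhibition and higher numbers for weaker inhibition), where compound 3 gives 90500 nM. Compound 1 `O=[N+]([O-])c1ccc(COc2ccc(OCCOCCNC3CCCC3)cc2)cc1` gives 20300 nM in this assay, and compound 2 `c1ccc(COc2ccc(COc3ccc(OCCOCCNC4CCCC4)cc3)cc2)cc1` gives 10000 nM. Compound 4 `Cc1ccc(COc2ccc(OCCOCCNC3CCCC3)cc2)cc1` differs from compound 3 by 4-methylphenyl in place of methyl on a saturated chain carbon bound to an oxygen on an aromatic ring. The step that bears on this most directly is a 4.5-fold higher number from compound 1 to compound 3 (0.65 log units; beyond the scatter), which runs the opposite way at the same place, while a 2.0-fold lower number from compound 1 to compound 2 (0.31 log units; beyond the scatter) shows that what replaces the nitro shifts the number only modestly. The expected step in this assay is therefore a 4.5-fold lower number from compound 3 to compound 4 (0.66 log units; beyond the scatter), toward a clearly lower number. Compound 4 is estimated at 20000 nM, with a range from 7000 nM to 55000 nM.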

Compound 4, half-maximal inhibitory concentration: 17200 nM
Compound 4: middle estimate off by 1.2-fold (0.07 log units), on the high side; measured number inside the range.
By their numbers in this assay, from the lowest: compounds 2, 4 and 1 (each within the scatter of the next, the first and the last beyond it); then compound 3.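

The drop seen in this assay is a 5.3-fold lower number from compound 3 to compound 4 (0.72 log units; beyond the scatter) and this shows that the nitro group is not needed for a lower number at this place, since a 4-methylphenyl in place of methyl also gives one. On the aromatic carbon, a 1.2-fold lower number from compound 1 to compound 4 (0.07 log units; within the scatter) and a 1.7-fold higher number from compound 2 to compound 4 (0.24 log units; within the scatter) both lie within the scatter, so methyl cannot be told apart from either nitro or benzyloxy. Going by these compounds, whether an amine or a carboxylic acid on that aromatic carbon would keep the number in this range stays open. No measurement given here accounts for these shifts.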